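The compounds below may be only part of what the source reports. "The series", "measured", "known", "first", "only" and "open" are said of these compounds alone.

Measured compounds:
compound 1, `CN(C)CCn1cnnc1-c1cc(Oc2ccc(NC(=O)N/N=C/c3cccc(Br)c3)cc2F)ccn1`: 830 nM
compound 2, `CN(C)CCn1cnnc1-c1cc(Oc2ccc(NC(=O)N/N=C/c3ccc(Cl)cc3)cc2F)ccn1`: 1370 nM
compound 3, `CN(C)CCn1cnnc1-c1cc(Oc2ccc(NC(=O)N/N=C/c3cc(Br)c(O)c(Br)c3)cc2F)ccn1`: > 100000 nM

In a functional assay on U-87MG ATCC cells (Homo sapiens) for cytotoxicity, read by MTT assay, with a stated time of 72 h (on this read-out lower numbers stand for stronger inhibition and higher numbers for weaker inhibition), compound 2 holds the higher of the two numbers, with compound 1 nearest at a 1.7-fold higher number from compound 1 to compound 2 (0.22 log units; within the scatter). The value of compound 3 is a limit of the assay, not a number. Compound 4, `CN(C)CCn1cnnc1-c1cc(Oc2ccc(NC(=O)N/N=C/c3ccc(F)cc3F)cc2F)ccn1`, differs from compound 2 by 2,4-difluorophenyl in place of 4-chlorophenyl on a carbon with a double bond to nitrogen. Among the measured compounds shown here, two measured steps bear on this: the swap of one halogenated phenyl for another gave a 1.7-fold higher number from compound 1 to compound 2 (0.22 log units; within the scatter), whereas the move to 3,5-dibromo-4-hydroxyphenyl gave an at least 72-fold higher number from compound 2 to compound 3 (1.86 log units; beyond the scatter). Compound 4 keeps a halogen-only phenyl, so the expected step of a 1.1-fold higher number from compound 2 to compound 4 (0.04 log units; within the scatter) is small. Compound 4 is estimated at 1500 nM, between 600 nM and 4000 nM.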

Compound 4, half-maximal inhibitory concentration: 1900 nM
Beside the measured number, compound 4's estimate is 1.3-fold (0.10 log units) below it; the measured number falls inside the stated range.
By their numbers in this assay, from the lowest: compounds 1, 2 and 4 (each within the scatter of the next, the first and the last beyond it). At a limit, above all of these: compound 3.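

In this assay, the 2,4-difluorophenyl group holds up about as well as 4-chlorophenyl, a 1.4-fold higher number from compound 2 to compound 4 (0.14 log units; within the scatter), so a second halogen-only phenyl is tolerated on this carbon. Yet these groups are not all interchangeable, since a 2.3-fold higher number from compound 1 to compound 4 (0.36 log units; beyond the scatter) is the first step among them to pass the scatter. The 3,5-dibromo-4-hydroxyphenyl group stays far apart, an at least 52-fold lower number from compound 3 to compound 4 (1.72 log units; beyond the scatter), and that reading rests on a limit: the limit of > 100000 nM in this assay, at which 1 of the 4 values shown sits.

Still open, going by these compounds, is whether the hydroxyl or the bromines set that group apart. Also open, on these data alone, is how this position responds to a phenyl carrying a methoxy group, an amine or a carboxylic acid.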